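Replacing the azetidine linker with an acrylamide-bearing ethyl chain

The compounds below may be only part of what the source reports. "The series", "measured", "known", "first", "only" and "open" are said of these compounds alone.

Compound 3 `C=C(C)C(=O)N1CC(Oc2ccc(Oc3c(-c4ccc(F)cc4)sc4cc(O)ccc34)cc2)C1` gives 14200 nM in a functional assay on Ishikawa cells (Homo sapiens) for antiproliferative activity, read by CCK-8 assay, with a stated time of 48 h (on this read-out higher numbers stand for weaker inhibition and lower numbers for stronger inhibition), the highest of the three numbers measured; compound 1 `C/C=C/C(=O)NCCOc1ccc(Oc2c(-c3ccc(F)cc3)sc3cc(O)ccc23)cc1` gives 12400 nM and compound 2 `O=C(/C=C/CNCCOc1ccc(Oc2c(-c3ccc(F)cc3)sc3cc(O)ccc23)cc1)N1CCC1` gives 6560 nM. The step to compound 4 `C=CC(=O)NCCOc1ccc(Oc2c(-c3ccc(F)cc3)sc3cc(O)ccc23)cc1` is 2-((vinylcarbonyl)amino)ethyl in place of 1-((1-methylethenyl)carbonyl)azetidin-3-yl on an oxygen on an aromatic ring. Among the measured compounds shown here, the closest precedent is the reverse exchange between compound 1 and compound 3, where a 1.1-fold higher number from compound 1 to compound 3 (0.06 log units; within the scatter), so this kind of swap barely moved the number. The remaining comparison, a 2.2-fold higher number from compound 2 to compound 3 (0.34 log units; beyond the scatter), involves a longer chain and bears less directly on compound 4. Compound 4 is therefore expected to sit near compound 1, with a 1.2-fold lower number from compound 3 to compound 4 (0.07 log units; within the scatter) and no change beyond the scatter. The estimate for compound 4 is 12000 nM, within 6000 nM to 25000 nM.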

Compound 4, half-maximal inhibitory concentration: > 25000 nM
Compound 4 gave a limit, no number; the forecaster's own chance of this, stated with the estimate: 5%; middle value at least 2.0-fold (0.31 log units) from the limit.
By their numbers in this assay, from the lowest: compounds 2, 1 and 3 (each within the scatter of the next, the first and the last beyond it). At a limit, above all of these: compound 4.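

In this assay compound 4 gives a limit and not a number: the limit of > 25000 nM in this assay, at which 1 of the 4 values shown sits. Vinyl in place of prop-1-en-1-yl on a carbonyl carbon gives an at least 2.0-fold higher number from compound 1 to compound 4 (0.30 log units; that floor lies within the scatter), and the change at the oxygen gives an at least 1.7-fold higher number from compound 3 to compound 4 (0.24 log units; that floor lies within the scatter), so neither floor separates compound 4 from those two compounds. Only an at least 3.8-fold higher number from compound 2 to compound 4 (0.58 log units; beyond the scatter) clears the scatter, which sets compound 4 apart from compound 2 alone.

From the compounds shown here alone, how far the true value of compound 4 lies beyond its limit stays open. So does how a longer chain or a terminal amine would read at this oxygen.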